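The source may hold more compounds than are shown below. What is called first, only, known or untested is meant among the compounds shown, and "the series" means these compounds.

Growth inhibition in a functional assay on M14 cells (Homo sapiens) for inhibition, read by sulforhodamine B assay, with a stated time of 48 h (a higher number here means a weaker inhibitor of growth, a lower number a stronger inhibitor of growth), measured compounds:
- compound 1 `O=C(NNC(=O)c1ccc2[nH]c(-c3ccc([N+](=O)[O-])o3)nc2c1)c1ccccc1` gives 15.6 ug/mL
- compound 2 `COc1cccc(C(=O)NNC(=O)c2ccc3[nH]c(-c4ccc([N+](=O)[O-])o4)nc3c2)c1` gives 7.81 ug/mL
- compound 3 `O=CNNC(=O)c1ccc2[nH]c(-c3ccc([N+](=O)[O-])o3)nc2c1` gives 31.3 ug/mL

Compound 3 , at 31.3 ug/mL, lies within the scatter of compound 1 and is separated beyond the scatter only from compound 2 , as a 4.0-fold higher number from compound 2 to compound 3 (0.60 log units; beyond the scatter) shows. The aromatic pair differs little, with a 2.0-fold lower number from compound 1 to compound 2 (0.30 log units; within the scatter).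

The open question is compound 4 `O=C(O)c1ccc2[nH]c(-c3ccc([N+](=O)[O-])o3)nc2c1`. The change is hydroxy in place of (formylamino)amino on a carbonyl carbon.

Among the measured compounds shown here, no measured step makes this change, so the evidence is indirect. The closest steps also cut back the group on the carbonyl side: a 2.0-fold higher number from compound 1 to compound 3 (0.30 log units; within the scatter) and a 4.0-fold higher number from compound 2 to compound 3 (0.60 log units; beyond the scatter). Both run toward a higher number, although only the second lies beyond the scatter. With three compounds, this is a weak guide. A modest move toward a higher number in this assay is therefore expected, and a result within the scatter of compound 3 would be unsurprising.

The expected step is a 1.4-fold higher number from compound 3 to compound 4 (0.16 log units; within the scatter).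

The estimated value for compound 4 is 45 ug/mL, with an expected range from 15 ug/mL to 125 ug/mL.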

Compound 4, concentration for 50% growth inhibition: 250 ug/mL
For compound 4 the middle estimate is 5.6-fold (0.74 log units) below the measured one; measured number above the stated range.
By their numbers in this assay, from the lowest: compounds 2, 1 and 3 (each within the scatter of the next, the first and the last beyond it); then compound 4.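

Working notes on the carbonyl position: in this assay, hydroxy in place of (formylamino)amino gives an 8.0-fold higher number from compound 3 to compound 4 (0.90 log units; beyond the scatter), a clear loss of growth inhibition and a larger step than any earlier one, of which the largest was a 4.0-fold higher number from compound 2 to compound 3 (0.60 log units; beyond the scatter). Among the compounds shown here, the earlier compounds showed only that the group on this carbonyl carbon, whose other neighbour is an aromatic carbon, could be cut back to the formyl end with a limited shift in the number; compound 4 shows that the carbonyl carbon bearing hydroxy instead lies well outside that range, so the position is not indifferent to what it carries. No measurement here bears on the reason for this step.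

The compounds shown do not separate the effect of having a carboxy group from the effect of losing the (formylamino)amino group. A methyl ester, a primary amide or a simple amine-derived amide on the same carbonyl carbon would help to tell these apart, and would show whether a short group other than hydroxy keeps the level of compound 3 .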